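The source may hold more compounds than are shown below. What is called first, only, known or untested is meant among the compounds shown, and "the series" means these compounds.

Compound 1, `N#CC1=C(N)Oc2c(c3nc4ccccc4nc3c3ccccc23)C12C(=O)N(Cc1cnnn1-c1ccc(S(N)(=O)=O)cc1)c1ccccc12`: 31200 nM
Compound 2, `N#CC1=C(N)Oc2c(N)cc3nc4ccccc4nc3c2C12C(=O)N(Cc1cnnn1-c1cccc(Br)c1)c1ccccc12`: 26100 nM

Of the compounds shown here, two sharing one core have been measured in a functional assay on HCT-116 cells (Homo sapiens) for antiproliferative activity, read by MTT assay, with a stated time of 48 h; on this read-out higher numbers stand for weaker inhibition and lower numbers for stronger inhibition. In that assay compound 1 gives 31200 nM, and compound 2 gives 26100 nM. The gap between these two numbers lies within the scatter of repeated measurements, so compound 2 cannot be set apart from compound 1; both sit in the same weak range. The two compounds differ from each other in more than one place. Among the compounds with values here, no single step between measured compounds can be read from them.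

Compound 3, `N#CC1=C(N)Oc2c(N)cc3nc4ccccc4nc3c2C12C(=O)N(Cc1cnnn1-c1ccc([N+](=O)[O-])cc1)c1ccccc12`, differs from compound 2 in one place only: 4-nitrophenyl in place of 3-bromophenyl on an aromatic nitrogen. Nothing measured here tells what this exchange does to the read-out. Within the data shown here, with no step of this kind to lean on, the expectation is a change of no more than the scatter in this assay, in no fixed direction.

Compound 3 is therefore expected to give about 25000 nM, with a likely range from 10000 nM to 60000 nM. This estimate means a step of a 1.0-fold lower number from compound 2 to compound 3 (0.02 log units; within the scatter), which is expected to stay within the scatter.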

Compound 3, half-maximal inhibitory concentration: > 50000 nM
Compound 3: a limit, no number; the forecaster's own chance of this, stated with the estimate: 15%; middle value at least 2.0-fold (0.30 log units) from the limit.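

In this assay, within the data shown here, the exchange of 3-bromophenyl for 4-nitrophenyl on an aromatic nitrogen of the five-membered ring gives the first step that can be read at this position: an at least 1.9-fold higher number from compound 2 to compound 3 (0.28 log units; that floor lies within the scatter). The reading for compound 3 is a limit of the assay and not a number: the limit of > 50000 nM in this assay, at which 1 of the 3 values shown sits. As far as these compounds go, the step therefore has only a floor, and with that floor inside the scatter, it shows that 4-nitrophenyl brings no gain in strength over 3-bromophenyl here, while the size of any loss stays unknown.

Among these compounds, compound 1 differs from the other two compounds in more than one place, so no step to it can be read, and this single exchange cannot separate the change from bromine to nitro from the shift between the 3- and 4-positions of the phenyl ring. What a plain phenyl, a 4-aminophenyl or a 4-carboxyphenyl would do at this position remains open, as does whether any group there could bring the read-out clearly below the weak range of these compounds.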